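The source may hold more compounds than are shown below. What is called first, only, known or untested is meant among the compounds shown, and "the series" means these compounds.

Three close relatives of one shared core have been tested in a functional assay for inhibition, with Homo sapiens as the target; a lower number here means a stronger inhibitor, a higher number a weaker inhibitor. Compound 1 `CCCc1nc(C)c2c(C)nn(CC)c(=O)n12` is the simplest of them. In this assay compound 1 reaches only the limit of the assay, > 48000 nM. Compound 2 `CCCc1nc(C)c2c(C)nn(CCC)c(=O)n12` differs from compound 1 by methyl in place of hydrogen on a saturated chain carbon, two bonds along the chain from an aromatic nitrogen. In this assay compound 2 likewise stops at the limit of the assay, > 48000 nM. Compound 3 `CCCc1nc(C)c2c(C)nn(CC(=O)O)c(=O)n12` carries carboxy in place of methyl on a saturated chain carbon bound to an aromatic nitrogen when set against compound 1. In this assay compound 3 also gives only a limit, > 48000 nM. Because all three values rest at one and the same limit (the limit of > 48000 nM in this assay, at which 3 of the 3 values shown sit), the steps a step that the two limits leave unreadable from compound 1 to compound 2, a step that the two limits leave unreadable from compound 1 to compound 3 and a step that the two limits leave unreadable from compound 2 to compound 3 cannot be read in size or direction. Compound 4 `CCCc1nc(C)c2c(C)nn(CC(=O)OCC)c(=O)n12` is the unmeasured relative, and it differs from compound 3 in one place: ethyl in place of hydrogen on an oxygen next to a carbonyl group. Among the measured compounds shown here, no measured step gives a readable size that would bear on this change, so the expected step of a number no higher from compound 3 to compound 4 (the limit leaves the size open) is set as no change from the limit. For compound 4 the estimate is therefore 48000 nM, expected to lie between 20000 nM and 100000 nM.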

Compound 4, half-maximal inhibitory concentration: > 48000 nM
Compound 4: a limit, no number; the forecaster's own chance of this, stated with the estimate: 80%; the middle value sits exactly at the limit.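

In this assay compound 4 also gives only a limit, > 48000 nM. The steps joining compound 4 to compound 1, compound 2 and compound 3 cannot be read in size or direction, because all the values rest at one limit: the limit of > 48000 nM in this assay, at which 4 of the 4 values shown sit. The compounds shown leave open how strongly any of them inhibits, and whether changing this chain on the shared core alters that at all.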